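The source may report more compounds than this note shows. Statements on the series, on what has been measured and on what is new or still open speak of the compounds shown alone.

In a functional assay on SJSA-1 cells (Homo sapiens) for antiproliferative activity, read by fluorescence, with a stated time of 72 h (on this read-out lower numbers stand for stronger inhibition and higher numbers for weaker inhibition), compound 1 `O=C(O)c1nc(-c2ccccc2)n(-c2cccc(Cl)c2F)c1-c1ccc(F)c(Cl)c1` gives 14000 nM. Compound 2 `O=C(O)c1nc(C2CCCCC2)n(-c2cccc(Cl)c2F)c1-c1ccc(F)c(Cl)c1` has a cyclohexyl in place of the phenyl and gives 13200 nM; the step of a 1.1-fold lower number from compound 1 to compound 2 (0.03 log units; within the scatter) lies within the scatter, so the two compounds stand together, and compound 2 has no number apart from that of compound 1 to be set against. For compound 3 `O=C(O)c1nc(-c2ccccc2)n(-c2cccc(Cl)c2)c1-c1cccc(Cl)c1` the result in this assay is "not determined" (no result reported), so it has no reported number. Compound 4 `NC(=O)c1nc(C2CCCCC2)n(-c2cccc(Cl)c2F)c1-c1ccc(F)c(Cl)c1` differs from compound 2 by amino in place of hydroxy on a carbonyl carbon. Among the measured compounds shown here, no measured step touches the carboxy group, so nothing measured bears on this change, and no direction can be drawn from it. The expectation is therefore a step of a 1.0-fold lower number from compound 2 to compound 4 (0.01 log units; within the scatter) of no size beyond the scatter, giving for compound 4 an estimate of 13000 nM between 3000 nM and 60000 nM.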

Compound 4, half-maximal inhibitory concentration: 4100 nM
Beside the measured number, compound 4's estimate is 3.2-fold (0.50 log units) above it, within the range that was stated.
By their numbers in this assay, from the lowest: compound 4; then compounds 2 and 1 (each within the scatter of the next).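

The carboxy group now proves to be a place where a change registers in this assay: amino in place of hydroxy on the carbonyl carbon gives (a 3.2-fold lower number from compound 2 to compound 4 (0.51 log units; beyond the scatter)). The phenyl-to-cyclohexyl exchange on the other side of the core did not do this, although hydroxy and amino count the same here, with one heavy atom and one hydrogen-bond donor each. Open, on these data alone, is whether carbamoyl gives a similar step with phenyl in place of cyclohexyl, as in compound 1, and what methylamino or methoxy would give on that carbonyl carbon. Nothing available explains why the number fell.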